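The source may report more compounds than this note shows. Statements on the series, on what has been measured and on what is new or still open speak of the compounds shown alone.

Measured in a functional assay on the whole organism with Mus musculus as the target; on this read-out lower numbers stand for an effect already at smaller amounts and higher numbers for an effect only at larger amounts of compound:
- Compound 1 `Cc1c(C)c2c(c(C)c1NC=O)CC(C)(C)O2`: > 100 mg/kg, a limit
- Compound 2 `CCC(=O)Nc1c(C)c(C)c2c(c1C)CC(C)(C)O2`: > 100 mg/kg, a limit
- Compound 3 `CCOC(=O)Nc1c(C)c(C)c2c(c1C)CC(C)(C)O2`: > 100 mg/kg, a limit

Compound 3 has no number, only the limit > 100 mg/kg. The whole series shares this position: the limit of > 100 mg/kg in this assay, at which 3 of the 3 values shown sit.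

Compound 4 `CNc1c(C)c(C)c2c(c1C)CC(C)(C)O2` carries methyl in place of ethoxycarbonyl on a nitrogen on an aromatic ring. For the measured compounds named here, three measured steps bear on this only loosely, since each changes the group on a carbonyl carbon: a step that the two limits leave unreadable from compound 1 to compound 2, a step that the two limits leave unreadable from compound 1 to compound 3 and a step that the two limits leave unreadable from compound 2 to compound 3. None has a readable size, and compound 4 alone lacks the carbonyl. A shift towards a smaller dose is expected, tentatively, as the estimated at least 1.6-fold lower number from compound 3 to compound 4 (0.22 log units; that floor lies within the scatter). The expected value for compound 4 is 60 mg/kg, with an estimated range of 15 mg/kg to 200 mg/kg.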

Compound 4, dose for 50% inhibition: 16.6 mg/kg
Estimate against measurement, compound 4: 3.6-fold (0.56 log units) above, and the stated range covers the measured number.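

Methyl in place of ethoxycarbonyl gives an at least 6.0-fold lower number from compound 3 to compound 4 (0.77 log units; beyond the scatter) and methyl in place of propanoyl gives an at least 6.0-fold lower number from compound 2 to compound 4 (0.77 log units; beyond the scatter) and methyl in place of formyl gives an at least 6.0-fold lower number from compound 1 to compound 4 (0.77 log units; beyond the scatter) on the nitrogen on an aromatic ring. For the compounds shown here, these are floors, and the earlier steps among compounds 1, 2 and 3, all on a carbonyl carbon, cannot be read. Only compound 4 has a number rather than a limit: the limit of > 100 mg/kg in this assay, at which 3 of the 4 values shown sit.

On these data alone, whether the free amine or a longer chain on the nitrogen would keep the lower dose remains open. With a single number in the series, no trend across nitrogen groups can be stated.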